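This account rests on a few compounds, and the source may have more. Where it says the series, first, only, none or still open, it means among the compounds named here.

Compound 1, `CCOC(=O)C1=C(C)NC(C)=C(C(=O)OCC)C1c1cnc(SC)n1Nc1ccccc1`: 1.69 nM in an assay on isolated protein (strain albino) for antagonist activity at Voltage-dependent L-type calcium channel subunit alpha-1C (Cavia porcellus); on this read-out higher numbers stand for weaker inhibition and lower numbers for stronger inhibition
Compound 2, `CCCOC(=O)C1=C(C)NC(C)=C(C(=O)OCCC)C1c1cnc(SC)n1Nc1ccccc1`: 2.29 nM in this assay

Of the compounds shown here, two have been measured, and compound 2 holds the higher of the two numbers; its nearest neighbour is compound 1, whose value sits within the scatter of that of compound 2, so the two cannot be told apart on the basis of these measurements. Compound 1 carries ethyl on both ester oxygens of the shared core, compound 2 propyl on both, and the numbers show no difference beyond the scatter between them.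

Compound 3, `CCCOC(=O)C1=C(C)NC(C)=C(C(=O)OC)C1c1cnc(SC)n1Nc1ccccc1`, is the next member. It is derived from compound 2 by one change: hydrogen in place of ethyl on a saturated chain carbon bound to an oxygen next to a carbonyl group. Going by the values given here, no measured pair in this set covers that particular exchange, so the expectation for compound 3 rests on the measured values alone. Since compound 1 and compound 2, which differ in the length of both ester chains, give numbers within the scatter of each other, shortening one ester chain in compound 2 is expected to move the number little, so the estimated step from compound 2 to compound 3 is a 1.1-fold lower number from compound 2 to compound 3 (0.06 log units; within the scatter), not beyond the scatter in either direction. Compound 3 is therefore expected to give about 2 nM in this assay, within a range from 0.8 nM to 5 nM.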

Compound 3, half-maximal inhibitory concentration: 2.4 nM
For compound 3 the middle estimate is 1.2-fold (0.08 log units) below the measured one, and the stated range covers the measured number.
By their numbers in this assay, from the lowest: compounds 1, 2 and 3 (each within the scatter of the next).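

In this assay, going by these compounds alone, the exchange of propoxycarbonyl for methoxycarbonyl on one ester gives a 1.0-fold higher number from compound 2 to compound 3 (0.02 log units; within the scatter) and is the first step that changes one place only. The earlier pair carried the same ester twice, so it could not speak for a single ester chain; this step does, and with propoxycarbonyl held on the other ester, propyl and methyl on this ester oxygen cannot be told apart. The data shown hold nothing that would explain this result.

On these data alone, what stays open is how far this holds beyond these two chains: a longer chain such as butyl, a branched one such as isopropyl, or a carboxylic acid or an amide in place of this ester might still give a number beyond the scatter. Whether methyl on this oxygen reads the same with ethyl or methyl on the other ester chain is also left open.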